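Methyl to trifluoromethyl: compound 1 to compound 4

The source may report more compounds than this note shows. Statements on the series, on what has been measured and on what is new or still open speak of the compounds shown alone.

Measured so far in an assay on HEK293 cells for inhibition of Voltage-dependent T-type calcium channel subunit alpha-1G (Homo sapiens), read by fluorescence, tested at 10 uM; a lower number here means less inhibition, a higher number more inhibition at the concentration tested (going by the name of the read-out):
compound 1 `CCCc1nc(-c2ccccc2)c(CNCCN2CCN(c3ccc(C)cc3)CC2)o1` gives 48.1%
compound 2 `CCCc1nc(-c2ccccc2)c(CNCCCN2CCN(c3cccc(C)c3C)CC2)o1` gives 55.2%
compound 3 `CCCc1nc(-c2ccccc2)c(CNCCCN2CCN(c3cccc(C)c3)CC2)o1` gives 47.8%

Compound 1 stands second highest of the three numbers in this assay. Its nearest neighbour is compound 3, within the scatter, and its furthest is compound 2, also within the scatter, so the three measured compounds cannot be ordered against each other on these numbers.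

Compound 4 `CCCc1nc(-c2ccccc2)c(CNCCN2CCN(c3ccc(C(F)(F)F)cc3)CC2)o1` differs from compound 1 in one place: trifluoromethyl in place of methyl on an aromatic carbon.

Among the compounds with values here, only one measured step is available, and it bears on the site rather than on the change itself: a number 7.4 percentage points lower from compound 2 to compound 3 (within the scatter). That step replaces a methyl on the aromatic carbon by hydrogen and stays within the scatter. Within the data shown here, no measured pair exchanges methyl for trifluoromethyl, so the series gives no direct reading for the change from compound 1 to compound 4. On this basis no step beyond the scatter is expected, and the step from compound 1 to compound 4 is estimated as a number 0.1 percentage points lower from compound 1 to compound 4 (within the scatter).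

Compound 4 is therefore expected to give about 48% in this assay, with an estimated range from 30% to 66%.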

Compound 4, a percentage reported as inhibition, at one concentration (the size of the read-out at that concentration, not a potency): 58.7%
Beside the measured number, compound 4's estimate is 10.7 percentage points below it; low and high end bracket the measured number.
By their numbers in this assay, from the lowest: compounds 3, 1, 2 and 4 (each within the scatter of the next, the first and the last beyond it).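

In this assay, within the data shown here, the change from 4-methylphenyl to 4-(trifluoromethyl)phenyl gives the first single-place step that lies beyond the scatter, a number 10.6 percentage points higher from compound 1 to compound 4 (beyond the scatter), although it remains modest. Among these compounds, the only earlier step, a number 7.4 percentage points lower from compound 2 to compound 3 (within the scatter), was a hydrogen-for-methyl exchange on an aromatic carbon that stayed within the scatter, so it showed no measurable response to that change, whereas the aromatic carbon para to a large group does respond to this exchange of methyl for trifluoromethyl. Nothing measured here accounts for the step.

Going by these compounds, it remains open whether the step is specific to trifluoromethyl or would also appear with a chlorine atom, a methoxy group or a nitrile at the same place, and where plain hydrogen there would fall relative to compound 1 and compound 4. On these data alone, it is also open whether the same exchange gives a step of similar size in the setting of a longer chain, as carried by compound 3, since this single pair cannot establish a trend beyond compound 1 and compound 4.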